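A few compounds are considered here, and "the series" means these few. Any claim that something is new, unique, unknown or untested is made for them only; others in the source may bear on it.

Of the compounds shown here, three built on one shared core have been tested in a functional assay on HEK293 cells for agonist activity at D(4) dopamine receptor (Homo sapiens), read by FLIPR; on this read-out lower numbers stand for smaller maximal responses and higher numbers for larger maximal responses. In this assay compound 1 `O=C(CN1CCC(c2cccc[n+]2[O-])CC1)Nc1cccc(-c2ccccc2)c1` gives 75%, compound 2 `O=C(CN1CCC(c2cccc[n+]2[O-])CC1)Nc1cccc(Cl)c1` gives 76%, and compound 3 `CSc1cccc(NC(=O)CN2CCC(c3cccc[n+]3[O-])CC2)c1` gives 56%. Compound 3 therefore stands lowest of the three: the steps of a number 19 percentage points lower from compound 1 to compound 3 (beyond the scatter) and a number 20 percentage points lower from compound 2 to compound 3 (beyond the scatter) both lie beyond the scatter, while the step of a number 1 percentage points higher from compound 1 to compound 2 (within the scatter) lies within it. Compound 4 `O=C(CN1CCC(c2cccc[n+]2[O-])CC1)Nc1cccc(C(F)(F)F)c1` differs from compound 3 in a single place: trifluoromethyl in place of methylsulfanyl on an aromatic carbon. Within the data shown here, no measured pair involves trifluoromethyl, so there is no direct step to lean on. What can be said is that methylsulfanyl at this position gave the lowest response of the set, whereas phenyl and chloro at the same position gave responses beyond the scatter higher in compounds 1 and 2. A partial return toward that level is expected, with the step of a number 12 percentage points higher from compound 3 to compound 4 (beyond the scatter) estimated but uncertain. Compound 4 is expected to give 68% in this assay, within a range of 52% to 84%.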

Compound 4, largest response reached (reported as efficacy), in percent of the reference or control that the assay uses: 75%
The estimate for compound 4 lay 7 percentage points below the measured number; measured number inside the range.
By their numbers in this assay, from the lowest: compound 3; then compounds 1, 4 and 2 (each within the scatter of the next).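

In this assay the change to trifluoromethyl gives a number 19 percentage points higher from compound 3 to compound 4 (beyond the scatter) and places compound 4 level with the other two compounds, as shown by a number 1 percentage points lower from compound 2 to compound 4 (within the scatter) and by no change at the digits printed from compound 1 to compound 4 (within the scatter) in turn. Phenyl, chloro and trifluoromethyl therefore give matching responses at this place on the aromatic ring, and among these four groups only methylsulfanyl in compound 3 stands apart. No measurement at hand explains why this one group differs.

As far as these compounds go, it remains open whether methoxy, which has oxygen where methylsulfanyl has sulfur, would stay near compound 3 or join the other three compounds. An amine, a carboxylic acid or a longer chain such as ethylsulfanyl at this place also remains untested among the compounds shown here.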